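Aryloxy-ketone tetrazoles: lipophilicity limits and the next analogue

The compounds below may be only part of what the source reports. "The series", "measured", "known", "first", "only" and "open" are said of these compounds alone.

compound 1 `CCCCCCCCc1ccc(OCC(=O)Cn2nnc(-c3ccc(Cl)cc3)n2)cc1`: > 8 in a physicochemical assay for lipophilicity, read by HPLC, tested at 5 mM; a higher number here means a more lipophilic compound, a lower number a more polar compound
compound 2 `CCCCCCCCc1ccc(OC(C)C(=O)Cn2nnc(-c3ccc(Cl)cc3)n2)cc1`: > 8 in this assay

The value of compound 1 in this assay is a limit of the assay, not a number. The value of compound 2 in this assay is likewise a limit. The step that the two limits leave unreadable from compound 1 to compound 2 is therefore unreadable, and the limit of > 8 in this assay, at which 2 of the 2 values shown sit, is all the series shows so far: both values sit at the same ceiling, so compound 2 stands at the upper limit of this assay with no number attached.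

Compound 3 `CC(Oc1ccc(Oc2ccc(Cl)cc2)cc1)C(=O)Cn1nnc(-c2ccc(Cl)cc2)n1` differs from compound 2 by 4-chlorophenoxy in place of octyl on an aromatic carbon. No measured step bears on this change, since the one step shown is masked by two limits. The expectation for compound 3 can therefore rest only on the structural change itself. Compound 3 is expected at 7, between 6.2 and 8. The estimated step from compound 2 to compound 3 is a number at least 1.00 log units lower from compound 2 to compound 3 (beyond the scatter), with a real chance that the assay again reports only a limit rather than a number.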

Compound 3, partition coefficient: 6.8
Estimate against measurement, compound 3: 0.20 log units above; the measured number falls inside the stated range.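

Replacing octyl with 4-chlorophenoxy at this aromatic carbon brings the series off the ceiling of this assay and gives its first readable change, a number at least 1.20 log units lower from compound 2 to compound 3 (beyond the scatter). Octyl and 4-chlorophenoxy have the same heavy-atom count, so this drop goes with exchanging a chain without a ring for an aromatic ring carrying oxygen and chlorine, not with a smaller substituent. Compound 2 has only a limit and not a number, so the full size of this change remains unknown, and the ceiling still accounts for most of the series: the limit of > 8 in this assay, at which 2 of the 3 values shown sit.

The step for the methyl on the saturated chain carbon cannot be read, which leaves its contribution unknown, and no pair shown tests that change on the 4-chlorophenoxy background, where a number might be obtained. As far as these compounds go, it also remains open whether a shorter chain such as butyl, or a phenoxy group without the chlorine, at this aromatic carbon would give a number in this assay, and where such a number would fall.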